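The source may report more compounds than this note shows. Statements on the series, on what has been measured and on what is new or still open speak of the compounds shown alone.

Measured in an ADME assay on HT-29 cells (Homo sapiens) for cytotoxicity, read by MTT assay, with a stated time of 72 h (a lower number here means a stronger inhibitor, a higher number a weaker inhibitor), each value a limit of the assay and not a number:

Compound 1 `COc1ccc(C2=C(c3cc(OC)c(OC)c(OC)c3)C(=O)C(OC(C)=O)C2)cc1`: < 1 ug/mL
Compound 2 `COc1ccc(C2=C(c3cc(OC)c(OC)c(OC)c3)C(=O)C(OC(C)=O)C2)cc1F`: < 1 ug/mL
Compound 3 `COc1ccc(C2=C(c3cc(OC)c(OC)c(OC)c3)C(=O)C(O)C2)cc1F`: < 1 ug/mL

Compound 2 is known only by a limit, < 1 ug/mL. All the data here rest on (the limit of < 1 ug/mL in this assay, at which 3 of the 3 values shown sit). The step to compound 4 `COc1ccc(C2=C(c3cc(OC)c(OC)c(OC)c3)C(=O)C(OC(C)=O)C2)cc1O` puts hydroxy in place of fluoro on an aromatic carbon, ortho to a methoxy group, turning 3-fluoro-4-methoxyphenyl into 3-hydroxy-4-methoxyphenyl: hydroxy in place of fluoro on an aromatic carbon.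

For the measured compounds named here, two measured steps bear on it. The closer one, with fluoro in place of hydrogen on an aromatic carbon, is a step that the two limits leave unreadable from compound 1 to compound 2. The other, with hydrogen in place of acetyl on an oxygen on a saturated carbon, is a step that the two limits leave unreadable from compound 2 to compound 3. Neither has a readable size, so in this assay no step beyond the scatter is expected, and no direction. The step expected is a step that the limit leaves unreadable from compound 2 to compound 4. For compound 4 the estimated value is 0.5 ug/mL, with an expected range of 0.1 ug/mL to 1.5 ug/mL.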

Compound 4, half-maximal inhibitory concentration: < 1 ug/mL
Compound 4: no number, only a limit; the forecaster's own chance of this, stated with the estimate: 85%; the middle value does not contradict the limit.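

Compound 4, like compound 1 and compound 2, is known in this assay only by a limit, so no new step can be read from compound 4 to either of them: the limit of < 1 ug/mL in this assay, at which 4 of the 4 values shown sit. The compounds shown leave open how far the hydrogen, fluoro and hydroxy compounds differ in strength, if they differ at all.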